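The source may report more compounds than this note shows. Statements on the series, on what has been measured and on what is new or still open speak of the compounds shown alone.

Measured in a functional assay on the whole organism (Gastrocnemius, strain Sprague-Dawley) for inhibition, with Rattus norvegicus as the target; a lower number here means that less compound is needed, a higher number that more compound is needed for the effect:
- compound 1 `N#Cc1ccc(-c2ccc(/C=N/N3C(=O)NC(=O)C3O)o2)cc1`: 0.025 umol/kg
- compound 2 `CC(=O)Nc1ccc(-c2ccc(/C=N/N3C(=O)NC(=O)C3O)o2)cc1`: > 0.107 umol/kg (a limit, not a number)
- compound 3 `O=C1CN(/N=C/c2ccc(-c3cccc(C(F)(F)F)c3)o2)C(=O)N1`: 0.05 umol/kg

Compound 2 is the only one of the three with a limit rather than a number. Compound 1 gives 0.025 umol/kg and compound 3 gives 0.05 umol/kg, two values within the usual scatter of each other.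

Compound 4 `O=C1NC(=O)N(/N=C/c2ccc(-c3ccc([N+](=O)[O-])cc3)o2)C1O` keeps the shared core of compound 2 and changes one group, nitro in place of acetamido on an aromatic carbon.

For the measured compounds named here, only one measured step bears on this change: an at least 4.2-fold higher number from compound 1 to compound 2 (0.63 log units; beyond the scatter). There, acetamido replaced cyano at the same place on the same core, and the step lies beyond the scatter. Going by the values given here, no nitro compound has been measured, so the size of the next step cannot be read directly from the data. Among the compounds with values here, compound 3 differs from the others in more than one place and offers no step to use.

Removing acetamido is expected to reverse much of the step to compound 2, moving the number down towards the value of compound 1 at 0.025 umol/kg. The expected change is an at least 2.6-fold lower number from compound 2 to compound 4 (0.42 log units; beyond the scatter).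

For compound 4 the estimated value in this assay is 0.04 umol/kg, with an expected range from 0.012 umol/kg to 0.15 umol/kg.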

Compound 4, dose for half-maximal effect: 0.015 umol/kg
Compound 4: the middle estimate sits 2.7-fold (0.43 log units) above what was measured; low and high end bracket the measured number.
By their numbers in this assay, from the lowest: compounds 4, 1 and 3 (each within the scatter of the next, the first and the last beyond it). At a limit, above all of these: compound 2.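

In this assay, for the compounds shown here, the earlier compounds showed only that acetamido on this aromatic carbon, para to a large group, gives a higher number than cyano; nitro now adds a third group at the same place on the shared core. Nitro in place of acetamido gives an at least 7.1-fold lower number from compound 2 to compound 4 (0.85 log units; beyond the scatter), so the higher number seen with acetamido is not reversed by cyano alone. Nitro in place of cyano gives a 1.7-fold lower number from compound 1 to compound 4 (0.22 log units; within the scatter), so these two groups cannot be told apart here, and among the three compounds sharing this core, only compound 2 stands out, with a limit rather than a number: the limit of > 0.107 umol/kg in this assay, at which 1 of the 4 values shown sits.

These compounds cannot separate which difference between acetamido and nitro matters, as the two groups differ both in their atoms and in the hydrogen-bond donor that acetamido carries. On these data alone, it also remains open how an amine or a carboxylic acid at this place would read, and whether either would stay with cyano and nitro or move towards acetamido.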